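The source may hold more compounds than are shown below. What is called first, only, known or untested is meant among the compounds shown, and "the series" means these compounds.

Measured so far:
- compound 1 `CC1=CC[C@H](C(C)(C)NC(=S)N/N=C/c2ccccc2O)CC1` — in a functional assay on NCI-H460 cells (Homo sapiens) for inhibition, read by sulforhodamine B assay, with a stated time of 48 h (on this read-out higher numbers stand for weaker inhibition of growth and lower numbers for stronger inhibition of growth), compound 1 gives 1900 nM
- compound 2 `CC1=CC[C@H](C(C)(C)NC(=S)N/N=C/c2ccc(N(C)C)cc2)CC1` — in this assay compound 2 gives 53400 nM

Of the two numbers in this assay, compound 2 stands highest, its value lying well beyond the scatter above that of compound 1; the two structures differ in more than one place, so only the two values themselves are shown, not a single step.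

The next compound is compound 3 `CC1=CC[C@H](C(C)(C)NC(=S)N/N=C/c2ccc(F)cc2)CC1`. It differs from compound 2 by fluoro in place of dimethylamino on an aromatic carbon. Among the compounds with values here, no measured pair shows this change on its own, so its effect can only be guessed. The account expects compound 3 to move the number down in this assay, by more than the scatter, with the estimated step of a 5.3-fold lower number from compound 2 to compound 3 (0.73 log units; beyond the scatter). On that basis compound 3 is expected to give about 10000 nM in this assay, within a range from 3000 nM to 40000 nM.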

Compound 3, concentration for 50% growth inhibition: > 100000 nM
Compound 3 ended at the assay's limit; the forecaster's own chance of this, stated with the estimate: 5%; middle value at least 10-fold (1.00 log units) away from the limit.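

In this assay the reading for compound 3 is a limit of the assay and not a number, so the steps to it are floors: the limit of > 100000 nM in this assay, at which 1 of the 3 values shown sits.

Fluoro in place of dimethylamino, para to a large group, gives an at least 1.8-fold higher number from compound 2 to compound 3 (0.27 log units; that floor lies within the scatter), so this pair does not establish a real difference between the two groups. Within the data shown here, the wider change, 4-fluorophenyl in place of 2-hydroxyphenyl, gives an at least 52-fold higher number from compound 1 to compound 3 (1.72 log units; beyond the scatter), the first step that differs in one place and lies beyond the scatter, and it shows that the group on the carbon with a double bond to nitrogen can decide much of the read-out.

As far as these compounds go, whether the lower number of compound 1 belongs to the hydroxy group itself or to where it sits stays open, as does how a 4-hydroxyphenyl or a plain phenyl group would read in this assay.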